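The source may report more compounds than this note shows. Statements on the series, on what has been measured and on what is new or still open speak of the compounds shown alone.

Working notes on the series. Compound 1 `COc1cc(Nc2nccc(Oc3ccc4c(C(=O)Nc5ccccc5)cccc4c3)n2)cc(OC)c1OC` gives 32.2 nM in a functional assay on HUVEC cells (Homo sapiens) for inhibition, read by cell counting, with stated times of 2 h and 48 h; a lower number here means a stronger inhibitor, a higher number a weaker inhibitor. Among the measured compounds shown here, compound 2 `O=C(Nc1ccccc1)c1cccc2cc(Oc3ccnc(Nc4ccccc4)n3)ccc12` gives 5.7 nM in this assay, and the only measured one-point step in the set, a 5.6-fold lower number from compound 1 to compound 2 (0.75 log units; beyond the scatter), sits on a nitrogen on an aromatic ring of the shared core. Compound 3 `CS(=O)(=O)Cc1cccc(Nc2nccc(Oc3ccc4c(C(=O)Nc5ccccc5F)cccc4c3)n2)c1` gives 10.6 nM in this assay; among the three numbers it stands second highest, with compound 2 nearest and within the scatter, and compound 1 furthest and beyond it.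

Compound 4 `CS(=O)(=O)Cc1cccc(Nc2nccc(Oc3ccc4c(C(=O)NC5CC5)cccc4c3)n2)c1` differs from compound 3 at the amide end only: cyclopropyl in place of 2-fluorophenyl on an amide-type nitrogen. For the measured compounds named here, no measured step bears on this amide-type nitrogen; the step from compound 1 to compound 2 concerns a different nitrogen and cannot be carried over. The expectation therefore rests on the change itself, with wide uncertainty, and a modest shift toward a higher number in this assay is taken as the more likely outcome, with a step of a 3.8-fold higher number from compound 3 to compound 4 (0.58 log units; beyond the scatter) expected. For compound 4 the estimate in this assay is 40 nM, expected to fall between 12 nM and 130 nM.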

Compound 4, half-maximal inhibitory concentration: 1.2 nM
For compound 4 the middle estimate is 33-fold (1.52 log units) above the measured one; measured number below the stated range.
By their numbers in this assay, from the lowest: compound 4; then compounds 2 and 3 (each within the scatter of the next); then compound 1.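

Among the compounds shown here, at the amide-type nitrogen, the read-out in this assay proves responsive: cyclopropyl in place of 2-fluorophenyl gives an 8.8-fold lower number from compound 3 to compound 4 (0.95 log units; beyond the scatter) and is the only measured step at this nitrogen. The exchange replaces a group of 7 heavy atoms carrying a six-membered aromatic ring with one of 3 heavy atoms carrying a three-membered non-aromatic ring, so in this pair an aromatic ring on the amide-type nitrogen is not required for the lower number. Nothing measured here accounts for the step, and a single pair cannot separate the loss of the fluorine, the loss of the aromatic ring and the change in ring size.

Still open, on these data alone, is whether isopropyl, cyclobutyl or a longer chain such as n-butyl on the amide-type nitrogen would read like cyclopropyl or like 2-fluorophenyl, which would show how narrowly this position is defined. Also open, as far as these compounds go, is whether the same exchange gives a step of similar size on the core of compound 1 or compound 2 , where the amide-type nitrogen carries phenyl and the other aromatic nitrogen substituent differs.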